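The source may hold more compounds than are shown below. What is called first, only, known or untested is meant among the compounds shown, and "the series" means these compounds.

Compound 1, `Cn1ncc([N+](=O)[O-])c1C(=O)Nc1ccc2nc(NC(=O)C3CCCCC3)sc2c1`, gives 0.026 ug/mL in a functional assay on WI-38 VA13 cells (Homo sapiens) for cytotoxicity; on this read-out higher numbers stand for an effect only at larger amounts of compound and lower numbers for an effect already at smaller amounts.
Compound 2, `O=C(Nc1ccc2nc(NC(=O)C3CCCCC3)sc2c1)c1cccc(F)c1`, gives 0.64 ug/mL in this assay.
Compound 3, `O=C(Nc1ccc2nc(NC(=O)C3CCCCC3)sc2c1)c1ccc(Br)cc1`, gives only a limit in this assay, > 4 ug/mL.

Of the two numbers measured, compound 2 holds the higher one, and the distance to the other is a 25-fold higher number from compound 1 to compound 2 (1.39 log units; beyond the scatter). Among the compounds with values here, compound 3 is the one value sitting at the limit of > 4 ug/mL in this assay, at which 1 of the 3 values shown sits.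

Compound 4, `Cc1nc(C)c(C(=O)Nc2ccc3nc(NC(=O)C4CCCCC4)sc3c2)s1`, differs from compound 2 by 2,4-dimethyl-1,3-thiazol-5-yl in place of 3-fluorophenyl on a carbonyl carbon. Both measured steps that alter the group on the carbonyl carbon bear on this change: an at least 6.2-fold higher number from compound 2 to compound 3 (0.79 log units; beyond the scatter), while the full span runs an at least 150-fold higher number from compound 1 to compound 3 (2.18 log units; beyond the scatter). The entering group is, like the group on compound 1, a five-membered aromatic ring with two hetero atoms, though it lacks the nitro of that group, so an effect somewhere between compound 1 and compound 2 seems most plausible, with the possibility of no change beyond the scatter.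

Compound 4 is therefore expected to show a 2.1-fold lower number from compound 2 to compound 4 (0.33 log units; beyond the scatter). The estimate for compound 4 is 0.3 ug/mL, within the range 0.05 ug/mL to 2 ug/mL.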

Compound 4, half-maximal effective concentration: 0.39 ug/mL
Compound 4: middle estimate off by 1.3-fold (0.11 log units), on the low side, within the range that was stated.
By their numbers in this assay, from the lowest: compound 1; then compounds 4 and 2 (each within the scatter of the next). At a limit, above all of these: compound 3.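

In this assay, a five-membered aromatic ring with 2 hetero atoms in place of the six-membered carbon ring on the carbonyl carbon does not by itself shift the number, the result being a 1.6-fold lower number from compound 2 to compound 4 (0.22 log units; within the scatter). Ring type alone therefore does not account for the strong effect of the nitro-bearing pyrazole, since the thiazole still gives a 15-fold higher number from compound 1 to compound 4 (1.18 log units; beyond the scatter). The position also remains sensitive to what is attached, although an at least 10-fold lower number from compound 3 to compound 4 (1.01 log units; beyond the scatter) rests on a limit of the assay for its first compound: the limit of > 4 ug/mL in this assay, at which 1 of the 4 values shown sits.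

The compounds shown leave open whether a nitro group on a phenyl or thiazole ring would bring the number down as far as the pyrazole does. They also leave open how an aminophenyl or a carboxyphenyl group would read in this place.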